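The source may report more compounds than this note shows. Statements on the series, on what has been measured and on what is new or still open speak of the compounds shown alone.

In a physicochemical assay for solubility, read by nephelometry, measured as kinetic solubility (on this read-out higher numbers stand for higher solubility and lower numbers for lower solubility), compound 3, `COc1cccc(Nc2cc(C)nc(NCc3ccccc3)n2)c1`, sits at the limit of this assay, > 250000 nM; that figure is a limit, not a measured number. Compound 1, `COc1cccc(Nc2nc(C)cc(N(C)C)n2)c1`, likewise gives the limit > 250000 nM. Compound 2, `Cc1cc(Nc2ccc(F)cc2)nc(NCc2ccccc2)n1`, also gives the limit > 250000 nM. The step that the two limits leave unreadable from compound 2 to compound 3 cannot be read, since both of its ends sit at the limit of > 250000 nM in this assay, at which 3 of the 3 values shown sit. Compound 4, `COc1cc(Nc2cc(C)nc(NCc3ccccc3)n2)ccc1F`, differs from compound 3 by fluoro in place of hydrogen on an aromatic carbon, a fluoro in place of hydrogen on an aromatic carbon. Within the data shown here, no measured step shows what such a change does; the one step that bears on compound 3 is unreadable. The step expected, a number no higher from compound 3 to compound 4 (the limit leaves the size open), is none beyond the scatter. Compound 4 is estimated at 250000 nM, between 100000 nM and 250000 nM.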

Compound 4, solubility: 180000 nM
Beside the measured number, compound 4's estimate is 1.4-fold (0.14 log units) above it; low and high end bracket the measured number.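

Among these compounds, compound 4 gives 180000 nM in this assay, the first reading here that is a number and not a limit. Fluoro in place of hydrogen, ortho to a methoxy group, gives an at least 1.3-fold lower number from compound 3 to compound 4 (0.14 log units; that floor lies within the scatter), and methoxy in place of hydrogen gives an at least 1.3-fold lower number from compound 2 to compound 4 (0.14 log units; that floor lies within the scatter). The full size of both steps stays unknown, because each starts from a limit: the limit of > 250000 nM in this assay, at which 3 of the 4 values shown sit.

Still open, on these data alone, is what another group on this same carbon, such as chloro, a nitrile or an amine, would give.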